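The source may hold more compounds than are shown below. What is called first, only, known or untested is meant among the compounds shown, and "the series" means these compounds.

Working notes on the series. Two compounds have been run in a functional assay for activation of Alpha-1A adrenergic receptor (Homo sapiens), read by calcium flux (on this read-out lower numbers stand for an effect already at smaller amounts and higher numbers for an effect only at larger amounts of compound), so far. Compound 1 `c1cnc(-c2ccccc2OCC2=NCCN2)nc1` gives 1260 nM in this assay, and compound 2 `c1ccc(-c2ncc[nH]2)c(OCC2=NCCN2)c1` gives 100 nM. Of these two numbers compound 2 stands lowest, with compound 1 the nearest and higher.

Compound 3 `Cn1nccc1-c1ccccc1OCC1=NCCN1` is the next to be measured in this assay. It differs from compound 2 in one place: 1-methyl-1H-pyrazol-5-yl in place of 1H-imidazol-2-yl on an aromatic carbon. A five-membered aromatic ring with 2 hetero atoms stays on the same aromatic carbon, but the hydrogen-bond donor of compound 2 is gone and a second hydrogen-bond acceptor is present. Going by the values given here, the only step that bears on this position is a 13-fold lower number from compound 1 to compound 2 (1.10 log units; beyond the scatter), a large one, which shows that the group at this carbon moves the number in this assay a long way; no measured step shows what loss of the donor alone does. Compound 3 is therefore expected to give a higher number than compound 2, by a moderate step, a 4.0-fold higher number from compound 2 to compound 3 (0.60 log units; beyond the scatter). The estimate for compound 3 in this assay is 400 nM, with a range from 120 nM to 1500 nM.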

Compound 3, half-maximal effective concentration: 39.8 nM
Compound 3: the middle estimate sits 10-fold (1.00 log units) above what was measured; measured number below the stated range.
By their numbers in this assay, from the lowest: compound 3; then compound 2; then compound 1.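

In this assay, a hydrogen-bond donor on the five-membered ring is not required at this aromatic carbon: 1-methyl-1H-pyrazol-5-yl, which has none, in place of 1H-imidazol-2-yl gives a 2.5-fold lower number from compound 2 to compound 3 (0.40 log units; beyond the scatter). Set against pyrimidin-2-yl, the same group gives a 32-fold lower number from compound 1 to compound 3 (1.50 log units; beyond the scatter), so the span seen at this carbon now reaches further than the earlier 13-fold lower number from compound 1 to compound 2 (1.10 log units; beyond the scatter). No measurement at hand gives a reason for this order of the three groups.

On these data alone, the step from 1H-imidazol-2-yl to 1-methyl-1H-pyrazol-5-yl changes the ring, the placing of its nitrogen atoms and the methyl group all at once, so the share of each in the lower number remains open. A 1-methyl-1H-imidazol-2-yl group and a 1H-pyrazol-5-yl group without the methyl would each separate these changes, while an ethyl group on the same ring nitrogen would show whether a larger alkyl group is accepted there.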